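From 4-chlorophenyl to 3-methoxyphenyl on the shared core

This account rests on a few compounds, and the source may have more. Where it says the series, first, only, none or still open, it means among the compounds named here.

In a functional assay on PANC-1 cells (Homo sapiens) for antiproliferative activity, read by CCK-8 assay, with a stated time of 72 h (a lower number here means a stronger inhibitor, a higher number a weaker inhibitor), compound 1 (`Cc1cc(Nc2cc(N3CCN(C)CC3)nc(Nc3ccc(S(N)(=O)=O)cc3)n2)n[nH]1`) gives 8760 nM and compound 2 (`Cc1cc(Nc2cc(N3CCN(C)CC3)nc(Nc3ccc(Cl)cc3)n2)n[nH]1`) gives 455 nM as the lower of the two numbers, which makes compound 2 the stronger inhibitor of this pair.

Compound 3 (`COc1cccc(Nc2nc(Nc3cc(C)[nH]n3)cc(N3CCN(C)CC3)n2)c1`) is the next case, with the change 3-methoxyphenyl in place of 4-chlorophenyl on a nitrogen on an aromatic ring in going from compound 2: 3-methoxyphenyl in place of 4-chlorophenyl on a nitrogen on an aromatic ring.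

Among the measured compounds shown here, only one measured step bears on this change, and only indirectly. In that step, a 19-fold lower number from compound 1 to compound 2 (1.28 log units; beyond the scatter) is a large change, beyond the scatter, with chloro in place of sulfamoyl on an aromatic carbon. For the measured compounds named here, it shows that a change on this aryl group can move the number strongly in this assay, but no measured compound carries a 3-methoxyphenyl group. Going by the values given here, the direction is therefore weakly supported, and a moderate rise is expected, as compound 2 holds the lower number so far.

The expected change is a 1.8-fold higher number from compound 2 to compound 3 (0.25 log units; within the scatter) in this estimate. Compound 3 is estimated at 800 nM, with an expected range from 250 nM to 2800 nM for the measurement.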

Compound 3, half-maximal inhibitory concentration: 693 nM
Estimate against measurement, compound 3: 1.2-fold (0.06 log units) above, and the stated range covers the measured number.
By their numbers in this assay, from the lowest: compounds 2 and 3 (each within the scatter of the next); then compound 1.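

In this assay the aryl group on this nitrogen can be exchanged without a readable shift, as 3-methoxyphenyl in place of 4-chlorophenyl gives a 1.5-fold higher number from compound 2 to compound 3 (0.18 log units; within the scatter) and the two groups cannot be told apart here, although they differ in substituent and in where it sits on the ring. Replacing 4-sulfamoylphenyl with 3-methoxyphenyl gives a 13-fold lower number from compound 1 to compound 3 (1.10 log units; beyond the scatter) and so matches in size the large step already seen with 4-chlorophenyl, which leaves compound 1 alone at the weak end of these three compounds and shows that the gain does not depend on the chloro group. No measurement on hand accounts for these numbers.

The three compounds do not show whether the high number of compound 1 belongs to the sulfamoyl group alone or would recur with a carboxylic acid or an amine on this aryl ring. Plain phenyl would show whether any substituent on the ring is needed at all, and the effects of substituent and ring position remain unseparated, since the two aryl groups with the lower numbers differ in both at once.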